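Replacing the pyrazole substituent in a benzimidazole series

The source may report more compounds than this note shows. Statements on the series, on what has been measured and on what is new or still open speak of the compounds shown alone.

Of the compounds shown here, two sharing one core have been measured in a functional assay for antagonist activity at Neuropeptides B/W receptor type 1 (Homo sapiens), read by cAMP accumulation; on this read-out lower numbers stand for stronger inhibition and higher numbers for weaker inhibition. Compound 1 `FC(F)(F)c1ccc2[nH]c(-c3ccc(-c4nnc[nH]4)cc3)nc2c1` gives 3080 nM, and compound 2 `FC(F)(F)c1ccc2[nH]c(-c3ccc(-c4c[nH]nc4C(F)(F)F)cc3)nc2c1` gives 1200 nM. Among the measured compounds shown here, the single step between them, a 2.6-fold lower number from compound 1 to compound 2 (0.41 log units; beyond the scatter), places compound 2 at the lower of the two numbers so far, the stronger of the pair.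

Compound 3 `Cn1cc(-c2ccc(-c3nc4cc(C(F)(F)F)ccc4[nH]3)cc2)cn1` has not yet been measured. It differs from compound 2 in one place: 1-methyl-1H-pyrazol-4-yl in place of 3-(trifluoromethyl)-1H-pyrazol-4-yl on an aromatic carbon. For the measured compounds named here, no measured step describes exactly this exchange; the only comparison available, a 2.6-fold lower number from compound 1 to compound 2 (0.41 log units; beyond the scatter), concerns the other end of the same position and shows that swapping the five-membered ring there moves the number by a modest amount. The change toward compound 3 removes the trifluoromethyl-bearing ring that came with that gain, so the expectation is that compound 3 gives a somewhat higher number, though a step within the scatter cannot be ruled out. The estimated step, a 2.1-fold higher number from compound 2 to compound 3 (0.32 log units; beyond the scatter), is expected to be small. For compound 3 the expected value in this assay is 2500 nM, within a range from 800 nM to 8000 nM.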

Compound 3, half-maximal inhibitory concentration: 1470 nM
For compound 3 the middle estimate is 1.7-fold (0.23 log units) above the measured one; measured number inside the range.
By their numbers in this assay, from the lowest: compounds 2 and 3 (each within the scatter of the next); then compound 1.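

The exchange of 3-(trifluoromethyl)-1H-pyrazol-4-yl for 1-methyl-1H-pyrazol-4-yl gives a 1.2-fold higher number from compound 2 to compound 3 (0.09 log units; within the scatter) in this assay and so leaves the number unchanged within the scatter, even though the entering group has no trifluoromethyl and no hydrogen-bond donor. Compared with 4H-1,2,4-triazol-3-yl, the 1-methyl-1H-pyrazol-4-yl group gives a 2.1-fold lower number from compound 1 to compound 3 (0.32 log units; beyond the scatter) and thus shows that a step beyond the scatter from this triazole does not depend on having a trifluoromethyl group on the pyrazole, since both pyrazole-bearing compounds give lower numbers than compound 1. Nothing measured here offers a reason for either step.

The exchange between compound 2 and compound 3 alters two features of the pyrazole at once. The methyl group and the trifluoromethyl group cannot be judged separately, and a plain 1H-pyrazol-4-yl group would be needed to separate them. Going by these compounds, it also remains open how this position would respond to a quite different kind of group, such as an amine, a carboxylic acid or a longer chain in place of the methyl group.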